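Closing the Amide Nitrogen into a Ring

The compounds below may be only part of what the source reports. "The series", "measured", "known", "first", "only" and "open" are said of these compounds alone.

Three compounds share one core and differ only in the group on the amide-type nitrogen. In a functional assay on the whole organism (strain Wistar) for inhibition, with Rattus norvegicus as the target, read by paw edema, with stated times of 60 min and 1 h, at a dose of 100 mg/kg by the oral route (a higher number here means more inhibition at the dose given (going by the name of the read-out), a lower number less inhibition), compound 1 `CCNC(=O)CC1CCc2cc(OC)c(OC)cc21` gives 15.6%. Compound 2 `COc1cc2c(cc1OC)C(CC(=O)NC(C)(C)C)CC2` gives 31.3%, and compound 3 `COc1cc2c(cc1OC)C(CC(=O)NC1CCCCC1)CC2` gives 50%. The steps between them all point the same way: a number 15.7 percentage points higher from compound 1 to compound 2 (beyond the scatter), a number 18.7 percentage points higher from compound 2 to compound 3 (beyond the scatter), and a number 34.4 percentage points higher from compound 1 to compound 3 (beyond the scatter). Compound 3 therefore stands highest of the three, with compound 2 nearest and compound 1 furthest.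

Compound 4 `COc1cc2c(cc1OC)C(CC(=O)N1CCCCC1)CC2` takes the next step from compound 3. The change is piperidin-1-yl in place of cyclohexylamino on a carbonyl carbon; the amide hydrogen is gone. Within the data shown here, none of the measured steps bears directly on this: each of them kept that hydrogen and varied only the group on the nitrogen, and no step from a cyclohexylamino to a piperidin-1-yl group has been seen. Among the measured compounds shown here, the measured steps show that this position is sensitive, so a step beyond the scatter in either direction is possible, but there is no measured step that tells its direction. The account therefore expects a modest fall, a number 15 percentage points lower from compound 3 to compound 4 (beyond the scatter), with wide uncertainty. For compound 4 the estimate in this assay is 35%, expected to lie between 10% and 60%.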

Compound 4, a percentage reported as inhibition, in the whole organism at one dose (the size of the read-out at that dose, not a potency): 18.8%
For compound 4 the middle estimate is 16.2 percentage points above the measured one; the measured number falls inside the stated range.
By their numbers in this assay, from the lowest: compounds 1 and 4 (each within the scatter of the next); then compound 2; then compound 3.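

In this assay the position had so far shown only rises, all with the amide hydrogen kept, and piperidin-1-yl brings the first fall (a number 31.2 percentage points lower from compound 3 to compound 4 (beyond the scatter)), a large step that goes against the direction of the earlier ones. The same group also stands under the tert-butyl compound (a number 12.5 percentage points lower from compound 2 to compound 4 (beyond the scatter)) and level with the ethyl compound (a number 3.2 percentage points higher from compound 1 to compound 4 (within the scatter)), so its number gives no sign of the rise seen along the open-nitrogen amides. A six-membered non-aromatic ring on the amide side is therefore not enough to hold the number, since cyclohexylamino and piperidin-1-yl both carry one, and the difference lies in the change that removes the hydrogen-bond donor and puts the nitrogen inside the ring, two things this single step does not separate.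

Going by these compounds, what a cyclohexyl(methyl)amino group would give on the same carbonyl carbon stays open, and with it whether the lost amide hydrogen or the closed ring weighs more. Nothing shown gives a reason for the fall.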